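The compounds below may be only part of what the source reports. "The series", "measured", "known", "first", "only" and "open" are said of these compounds alone.

In a functional assay on MCF7 cells (Homo sapiens) for cytotoxicity, read by sulforhodamine B assay (a lower number here means that less compound is tolerated, a higher number that more compound is tolerated), compound 1 `COc1ccc(/C=N\NC(=S)NC(C)(C)CCC[C@](C)(O)[C@@H]2CC=C(C)CC2)cc1` gives > 100000 nM, which is a limit of the assay and not a number. Compound 2 `CC1=CC[C@@H]([C@@](C)(O)CCCC(C)(C)NC(=S)N/N=C\c2ccccc2[N+](=O)[O-])CC1` gives > 100000 nM, and this too is only a limit. Compound 2 therefore has no exact position on the scale. It differs from compound 1 by carrying 2-nitrophenyl in place of 4-methoxyphenyl on a carbon with a double bond to nitrogen. That one measured comparison, a step that the two limits leave unreadable from compound 1 to compound 2, has no readable size, so it cannot show how much this part of the molecule matters. What the data do show is the limit of > 100000 nM in this assay, at which 2 of the 2 values shown sit.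

Going by the values given here, compound 3 `CC1=CC[C@@H]([C@@](C)(O)CCCC(C)(C)NC(=S)N/N=C\c2cccc([N+](=O)[O-])c2)CC1` keeps the rest of compound 2 and changes only this aromatic group: 3-nitrophenyl in place of 2-nitrophenyl on a carbon with a double bond to nitrogen. In words, 3-nitrophenyl stands in place of 2-nitrophenyl on a carbon with a double bond to nitrogen. Given (the limit of > 100000 nM in this assay, at which 2 of the 2 values shown sit), no step beyond the usual scatter is expected in this assay, and no direction can be argued. The expected change is a number no higher from compound 2 to compound 3 (the limit leaves the size open). For compound 3, the estimate is 100000 nM, with an expected range from 40000 nM to 250000 nM, and another limit rather than a number is the likeliest report.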

Compound 3, concentration lethal to 50% of the cells: 47300 nM
Compound 3: the middle estimate sits 2.1-fold (0.33 log units) above what was measured; measured number inside the range.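

In this assay, going by these compounds alone, this is the first change that can be read. Within the data shown here, with the same atoms joined differently, 3-nitrophenyl in place of 2-nitrophenyl on a carbon with a double bond to nitrogen gives an at least 2.1-fold lower number from compound 2 to compound 3 (0.32 log units; beyond the scatter) and so shows that the way this aromatic group is built can alter the read-out, which the first pair of compounds could not show. Replacing 4-methoxyphenyl with 3-nitrophenyl at the same place gives an at least 2.1-fold lower number from compound 1 to compound 3 (0.32 log units; beyond the scatter) as well, and since both steps start from a limit of the assay, each gives only a smallest size and not the full one. Compound 3 is the only one of the three with an exact position on the scale, while the other two remain at the limit: the limit of > 100000 nM in this assay, at which 2 of the 3 values shown sit.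

From the compounds shown here alone, how far the number can fall at this place remains open, as does whether the change depends on the nitro group itself or on its arrangement in 3-nitrophenyl. Compounds carrying 4-nitrophenyl, 3-methoxyphenyl or 3-aminophenyl, or a phenyl ring bearing a carboxylic acid, would help to separate these possibilities.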